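A few compounds are considered here, and "the series" means these few. Any claim that something is new, unique, unknown or untested is made for them only; others in the source may bear on it.

Measured so far:
Compound 1, `Cc1nnc(SCC(=O)c2ccccc2)n1N1C(=O)c2ccccc2C1=O`, in a functional assay on MKN-45 cells (Homo sapiens) for cytotoxicity, read by MTT assay, with a stated time of 48 h (a lower number here means a stronger inhibitor, a higher number a weaker inhibitor), gives > 200000 nM, which is a limit of the assay and not a number.
Compound 2, `CSc1nnc(C)n1N1C(=O)c2ccccc2C1=O`, in this assay gives > 200000 nM, also a limit.
Compound 3, `C=CCSc1nnc(CC)n1N1C(=O)c2ccccc2C1=O`, in this assay gives > 200000 nM, again a limit.

All three compounds share the same core, and each differs from the others only in the groups hanging from it. Compound 3 therefore stands at a limit with no number of its own, and the two other values sit at that same limit, as summed up in the limit of > 200000 nM in this assay, at which 3 of the 3 values shown sit. The next compound, compound 4 `CCc1nnc(SCC(=O)c2ccc(C)cc2)n1N1C(=O)c2ccccc2C1=O`, differs from compound 3 by (4-methylphenyl)carbonyl in place of vinyl on a saturated chain carbon bound to a sulfur. Among the measured compounds shown here, only one measured step touches that same place on the chain, namely a step that the two limits leave unreadable from compound 1 to compound 2, and with both of its ends at the limit its size cannot be read. Compound 1 carries a benzoyl close in kind to the group entering in compound 4, and compound 1 shows only a limit. No change beyond the scatter is therefore expected in this assay, and the expected step that the limit leaves unreadable from compound 3 to compound 4 is accordingly small. For compound 4 the estimate is 250000 nM, within a range from 100000 nM to 1000000 nM, most likely reported again only as a limit.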

Compound 4, half-maximal inhibitory concentration: > 200000 nM
Compound 4: only a limit was reported; the forecaster's own chance of this, stated with the estimate: 85%; the middle value lies beyond the limit too.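

Compound 3 and compound 4 both stand at a limit and not at a number, so the step between them cannot be read, and the same holds for all four values: the limit of > 200000 nM in this assay, at which 4 of the 4 values shown sit.

The compounds shown leave open whether any change of the groups on the shared core would give a readable value in this assay.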